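A Methoxyphenyl Variant of Compound 3

The source may hold more compounds than are shown below. What is called first, only, known or untested is meant among the compounds shown, and "the series" means these compounds.

Of the compounds shown here, three sharing one core have been tested in a functional assay on HT-29 cells (Homo sapiens) for antiproliferative activity, read by sulforhodamine B assay, with a stated time of 72 h; a lower number here means a stronger inhibitor, a higher number a weaker inhibitor. Compound 1 `S=C(NCc1ccccc1)N/N=C/c1ccc2ccccc2n1` gives 75700 nM, compound 2 `NC(=S)N/N=C/c1ccc2ccccc2n1` gives 100000 nM, and compound 3 `Cc1ccc(NC(=S)N/N=C/c2ccc3ccccc3n2)cc1` gives 85500 nM. Compound 3 thus stands second highest of the three numbers, with compound 1 nearest and compound 2 furthest, though both gaps are within the scatter. Compound 4 `COc1cccc(NC(=S)N/N=C/c2ccc3ccccc3n2)c1` differs from compound 3 by 3-methoxyphenyl in place of 4-methylphenyl on an amide-type nitrogen. Within the data shown here, no measured step swaps one substituted phenyl for another; the closest guides are a 1.1-fold higher number from compound 1 to compound 3 (0.05 log units; within the scatter) and a 1.2-fold lower number from compound 2 to compound 3 (0.07 log units; within the scatter), both small. A step within the scatter is therefore expected, a 1.0-fold lower number from compound 3 to compound 4 (0.00 log units; within the scatter). Compound 4 is expected to give about 85000 nM, between 40000 nM and 150000 nM.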

Compound 4, half-maximal inhibitory concentration: 82400 nM
Compound 4: the middle estimate sits 1.0-fold (0.01 log units) above what was measured; low and high end bracket the measured number.
By their numbers in this assay, from the lowest: compounds 1, 4, 3 and 2 (each within the scatter of the next).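

Putting 3-methoxyphenyl in place of 4-methylphenyl on the amide-type nitrogen adds an oxygen and a hydrogen-bond acceptor, yet the result is a 1.0-fold lower number from compound 3 to compound 4 (0.02 log units; within the scatter). Compound 4 also stays within the scatter when hydrogen stands at this place, with a 1.2-fold lower number from compound 2 to compound 4 (0.08 log units; within the scatter), and when benzyl stands there, with a 1.1-fold higher number from compound 1 to compound 4 (0.04 log units; within the scatter). So a new substituted phenyl again leaves the number unmoved, and no measurement here offers an explanation for that. From the compounds shown here alone, whether an amine, a carboxylic acid or a longer chain on this nitrogen would give a step beyond the scatter stays open.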